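The compounds below may be only part of what the source reports. "The series", "measured", "known", "first", "only" and "open" are said of these compounds alone.

Working notes on a small series sharing one core, followed in an ADME assay on BaF3 cells (Mus musculus) for cytotoxicity, read by CellTiter-Glo and CCK-8 assay, with a stated time of 72 h; a lower number here means a stronger inhibitor of growth, a higher number a weaker inhibitor of growth. Compound 1 (`CCC(=O)NCc1cccc(C(=O)Nc2ccc(C)c(Nc3nccc(-c4cccnc4)n3)c2)c1`) gives 4750 nM. Compound 2 (`Cc1ccc(NC(=O)c2ccc(CNC(=O)c3cccnc3)c(C(F)(F)F)c2)cc1Nc1nccc(-c2cccnc2)n1`) gives 8330 nM, and these two values lie within the usual scatter of each other. Compound 3 (`CCC(=O)Nc1ccc(C(=O)Nc2ccc(C)c(Nc3nccc(-c4cccnc4)n3)c2)cc1`) is reported only as a limit, > 10000 nM. Still to be measured is compound 4 (`CCC(=O)N(CCN(C)C)Cc1ccc(C(=O)Nc2ccc(C)c(Nc3nccc(-c4cccnc4)n3)c2)cc1`). Compared with compound 3, it carries ((2-(dimethylamino)ethyl)(propanoyl)amino)methyl in place of propanoylamino on an aromatic carbon, para to a large group: ((2-(dimethylamino)ethyl)(propanoyl)amino)methyl in place of propanoylamino on an aromatic carbon.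

For the measured compounds named here, no measured step guides this change, so the expectation rests only on compound 1 at 4750 nM and compound 2 at 8330 nM. A modest move toward stronger growth inhibition is expected, with the estimated step of an at least 2.5-fold lower number from compound 3 to compound 4 (0.39 log units; beyond the scatter). As far as these compounds go, the start of that step is a limit and not a number, so its size remains open. For compound 4 the estimated value is 4000 nM, with an expected range of 1200 nM to 10000 nM.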

Compound 4, concentration for 50% growth inhibition: > 10000 nM
Compound 4 was reported as a limit; the forecaster's own chance of this, stated with the estimate: 20%; middle value at least 2.5-fold (0.39 log units) away from the limit.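

In this assay, compound 3 and compound 4 are both reported only as limits, so no step between them can be read: the limit of > 10000 nM in this assay, at which 2 of the 4 values shown sit.

The compounds shown leave open whether ((2-(dimethylamino)ethyl)(propanoyl)amino)methyl in place of propanoylamino changes growth inhibition at all in this assay.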